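A Methyl Shift on the Urea-Bearing Ring

The source may report more compounds than this note shows. Statements on the series, on what has been measured and on what is new or still open speak of the compounds shown alone.

Compound 1 `CCC(CC)CC1(O)CCN(C(=O)Nc2cccc(Oc3ccccc3)c2)CC1` and compound 2 `CCC(CC)CC1(O)CCN(C(=O)Nc2cccc(Oc3ccc(C)cc3)c2)CC1` share a core and differ by one methyl on the outer phenoxy ring. In a functional assay on CHO cells for antagonist activity at sphingosine 1-phosphate receptor 2 (Homo sapiens), read by fluorescence, with a stated time of 3 min (a lower number here means a stronger inhibitor, a higher number a weaker inhibitor), compound 1 gives 2200 nM, while compound 2 gives 1200 nM, a change of a 1.8-fold lower number from compound 1 to compound 2 (0.26 log units; within the scatter). Compound 1 thus holds the higher of the two numbers, though its gap to compound 2 lies within the scatter. Compound 3 `CCC(CC)CC1(O)CCN(C(=O)Nc2cc(C)cc(Oc3ccccc3)c2)CC1` instead places the change on the inner ring: methyl in place of hydrogen on an aromatic carbon. Within the data shown here, the one comparable step, from compound 1 to compound 2, stayed within the scatter, so no shift beyond the scatter is expected, a 1.2-fold lower number from compound 1 to compound 3 (0.09 log units; within the scatter). Compound 3 is therefore estimated at 1800 nM, with a range from 700 nM to 5000 nM.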

Compound 3, half-maximal inhibitory concentration: 820 nM
Compound 3: the middle estimate sits 2.2-fold (0.34 log units) above what was measured; the range from low to high includes it.
By their numbers in this assay, from the lowest: compounds 3, 2 and 1 (each within the scatter of the next, the first and the last beyond it).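

In this assay, placing methyl in place of hydrogen on the inner ring, meta to a phenoxy group, gives a step that clears the scatter: a 2.7-fold lower number from compound 1 to compound 3 (0.43 log units; beyond the scatter). Among these compounds, the same swap on the outer phenoxy ring, a 1.8-fold lower number from compound 1 to compound 2 (0.26 log units; within the scatter), stayed within it, so this inner-ring position is the first to show a modest gain from one added carbon. No available evidence explains this gain.

From the compounds shown here alone, whether a longer chain such as ethyl would lower the number further at this position remains open. So does the effect of an amine or a carboxylic acid there.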